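The compounds below may be only part of what the source reports. "The series", "measured", "known", "first", "only" and "open" are said of these compounds alone.

Compound 1 `COc1cc(CC(COCc2ccccc2)COCc2ccccc2)nc(OC)n1` gives 300 nM in a functional assay on HepG2 cells (Homo sapiens) for antiproliferative activity, read by MTT assay, with a stated time of 72 h; a higher number here means a weaker inhibitor, a lower number a stronger inhibitor. Compound 2 `O=c1cc(CC(COCc2ccccc2)COCc2ccccc2)[nH]c(=O)[nH]1` reaches only a limit of this assay, > 100000 nM. Compound 3 `COc1cc(CC(O)COCc2ccccc2)nc(OC)n1` likewise reaches only a limit, > 100000 nM.

The two cores differ in that compound 2 carries a group of 8 heavy atoms (4 carbon, 2 nitrogen, 2 oxygen; one six-membered aromatic ring with 2 hetero atoms) in place of a group of 10 heavy atoms (6 carbon, 2 nitrogen, 2 oxygen; one six-membered aromatic ring with 2 hetero atoms), on a saturated chain carbon, three bonds along the chain from two oxygens on a saturated carbon, and this step is an at least 330-fold higher number from compound 1 to compound 2 (2.52 log units; beyond the scatter). The second change, (hydroxy in place of (benzyloxy)methyl on a saturated chain carbon bound to two saturated chain carbons), makes a step of an at least 330-fold higher number from compound 1 to compound 3 (2.52 log units; beyond the scatter). Compound 4 `O=c1cc(CC(O)COCc2ccccc2)[nH]c(=O)[nH]1` is not yet measured; it carries the same change as compound 3, (hydroxy in place of (benzyloxy)methyl on a saturated chain carbon bound to two saturated chain carbons), made on the core of compound 2. Since compound 2 already sits at the limit of > 100000 nM in this assay, at which 2 of the 3 values shown sit, compound 4 is expected to stay there as well, with an expected step that the limit leaves unreadable from compound 2 to compound 4. The estimate for compound 4 in this assay is 300000 nM, most likely again reported only as a limit.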

Compound 4, half-maximal inhibitory concentration: > 100000 nM
Compound 4: only a limit was reported; the forecaster's own chance of this, stated with the estimate: 95%; the middle value lies beyond the limit too.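

Compound 2 and compound 4 both stand at a limit of this assay, so no step between them can be read: the limit of > 100000 nM in this assay, at which 3 of the 4 values shown sit.

The compounds shown leave open whether hydroxy in place of (benzyloxy)methyl changes anything on the core of compound 2.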